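The source may hold more compounds than are shown below. What is called first, only, known or untested is meant among the compounds shown, and "the series" means these compounds.

Compound 1 `C=CC(=O)Nc1cccc(Oc2nc(Nc3ccc(OC)cc3)nc3c2CSCC3)c1`: 4220 nM
Compound 2 `C/C=C/C(=O)Nc1cccc(Oc2nc(Nc3ccc(OC)cc3)nc3c2CSCC3)c1`: 22200 nM

In a functional assay on A549 cells (Homo sapiens) for antiproliferative activity, read by MTT assay, with a stated time of 72 h (on this read-out lower numbers stand for stronger inhibition and higher numbers for weaker inhibition), compound 2 gives 22200 nM, the higher of the two numbers, and the nearest value is that of compound 1 at 4220 nM. Next in the series is compound 3 `CC/C=C/C(=O)Nc1cccc(Oc2nc(Nc3ccc(OC)cc3)nc3c2CSCC3)c1`, not yet measured. The change is methyl in place of hydrogen on a saturated chain carbon bound to a double-bonded chain carbon, turning prop-1-en-1-yl into but-1-en-1-yl. Going by the values given here, only one measured step bears on this: a 5.3-fold higher number from compound 1 to compound 2 (0.72 log units; beyond the scatter), which also alters the chain on the carbonyl. A single step sets no trend, so a smaller change in the same direction is expected, possibly within the scatter. The expected result is a 1.2-fold higher number from compound 2 to compound 3 (0.09 log units; within the scatter). Compound 3 is estimated at 27000 nM, with an expected range of 11000 nM to 65000 nM.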

Compound 3, half-maximal inhibitory concentration: 20100 nM
Beside the measured number, compound 3's estimate is 1.3-fold (0.13 log units) above it, and the stated range covers the measured number.
By their numbers in this assay, from the lowest: compound 1; then compounds 3 and 2 (each within the scatter of the next).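

In this assay, going by these compounds alone, the added methyl, turning prop-1-en-1-yl into but-1-en-1-yl, gives a 1.1-fold lower number from compound 2 to compound 3 (0.04 log units; within the scatter) and so leaves the number unmoved, which the single earlier step could not show. The loss seen with a 5.3-fold higher number from compound 1 to compound 2 (0.72 log units; beyond the scatter) thus does not deepen with this extension of the chain: a 4.8-fold higher number from compound 1 to compound 3 (0.68 log units; beyond the scatter) is also beyond the scatter, and compound 1, with the vinyl group, keeps the lowest number of the three. No available evidence accounts for either the loss or its levelling off.

Going by these compounds, whether a longer chain would stay at this level remains open. So does whether an amine such as dimethylamino on the chain would bring the number back toward compound 1 at 4220 nM in this read-out.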